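Methoxy to isopropyl in a series without clear steps

The compounds below may be only part of what the source reports. "The series", "measured", "known", "first", "only" and "open" are said of these compounds alone.

Values in a functional assay on HepG2 cells (Homo sapiens) for cytotoxicity, read by MTT assay, with a stated time of 48 h (on this read-out lower numbers stand for stronger inhibition and higher numbers for weaker inhibition), so far:
Compound 1 `O=C1CS/C(=N/c2ccccc2)N1Cc1ccncc1` gives 26000 nM
Compound 2 `O=C1/C(=C\c2ccccc2)S/C(=N/c2ccccc2)N1Cc1ccncc1` gives 25200 nM
Compound 3 `COc1ccc(/C=C2/S/C(=N/c3ccccc3)N(Cc3ccncc3)C2=O)cc1` gives 19100 nM

Compound 3 stands among three values that all lie within the usual scatter of one another, so these numbers do not separate it from compound 1 or compound 2. The next structure is compound 4 `CC(C)c1ccc(/C=C2/S/C(=N/c3ccccc3)N(Cc3ccncc3)C2=O)cc1` and its difference from compound 3 is isopropyl in place of methoxy on an aromatic carbon which amounts to isopropyl in place of methoxy on an aromatic carbon, para to a large group. Going by the values given here, one measured step bears on this change: a 1.3-fold lower number from compound 2 to compound 3 (0.12 log units; within the scatter) came with methoxy in place of hydrogen on an aromatic carbon and stayed within the scatter. Among the compounds with values here, no measured compound yet carries isopropyl. A step beyond the scatter is therefore not expected in this assay and neither direction is favoured. The estimated 1.1-fold lower number from compound 3 to compound 4 (0.03 log units; within the scatter) is expected to remain small. For compound 4 the expected value is 18000 nM within an estimated range of 9000 nM to 35000 nM.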

Compound 4, half-maximal inhibitory concentration: 32300 nM
Compound 4: middle estimate off by 1.8-fold (0.25 log units), on the low side; low and high end bracket the measured number.
By their numbers in this assay, from the lowest: compounds 3, 2, 1 and 4 (each within the scatter of the next).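

In this assay, isopropyl in place of methoxy on this aromatic carbon gives a 1.7-fold higher number from compound 3 to compound 4 (0.23 log units; within the scatter), and isopropyl in place of hydrogen gives a 1.3-fold higher number from compound 2 to compound 4 (0.11 log units; within the scatter). Together with the earlier methoxy step, this means that hydrogen, methoxy and isopropyl at this position cannot be told apart on these numbers, and that exchanging methoxy, which has a hydrogen-bond acceptor, for isopropyl, which has none, stays within the scatter. No supporting evidence is available to explain these values.

As far as these compounds go, whether any group at this position can move the number beyond the scatter remains open, since an amine or a carboxylic acid on the same aromatic carbon would test a different kind of group. From the compounds shown here alone, it also remains open whether changes elsewhere on the shared core would separate these compounds.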